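This account rests on a few compounds, and the source may have more. Where it says the series, first, only, none or still open, it means among the compounds named here.

Three compounds share one core, with a thiophene or furan ring on one saturated ring carbon and an aryl ketone on the next. Compound 1 `COc1cc(-c2nnc3n2NC(c2cccs2)C(C(=O)c2ccccc2)S3)cc(OC)c1OC` carries an unsubstituted phenyl ketone and gives 86300 nM in a functional assay on PC-3 cells (Homo sapiens) for cytotoxicity, read by MTT assay, with a stated time of 48 h; a lower number here means a stronger inhibitor, a higher number a weaker inhibitor. Going by the values given here, compound 2 `COc1cc(-c2nnc3n2NC(c2cccs2)C(C(=O)c2ccc(F)cc2)S3)cc(OC)c1OC` gives 27400 nM, and the step of a 3.1-fold lower number from compound 1 to compound 2 (0.50 log units; beyond the scatter) is the only single change measured here. Compound 3 `COc1cc(-c2nnc3n2NC(c2ccco2)C(C(=O)c2ccc(C(F)(F)F)cc2)S3)cc(OC)c1OC` gives 77500 nM. Among the three numbers compound 3 stands second highest: its value and that of compound 1 lie within the scatter of each other, while compound 2 shows a clearly lower number than compound 3.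

Compound 4 `COc1cc(-c2nnc3n2NC(c2ccco2)C(C(=O)c2cccc4ccccc24)S3)cc(OC)c1OC` differs from compound 3 in one place: naphthalen-1-yl in place of 4-(trifluoromethyl)phenyl on a carbonyl carbon. Among the compounds with values here, the one measured step, from compound 1 to compound 2, also alters the ring on the carbonyl carbon, but by adding a single fluorine, and it was modest in size. Nothing measured here speaks directly to swapping a fluorinated ring for a second fused ring, so the expectation for compound 4 in this assay is a step of no more than modest size, with the direction uncertain, a 1.3-fold lower number from compound 3 to compound 4 (0.11 log units; within the scatter). Compound 4 is therefore estimated at 60000 nM, within a range from 20000 nM to 180000 nM.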

Compound 4, half-maximal inhibitory concentration: > 100000 nM
Compound 4: only a limit was reported; the forecaster's own chance of this, stated with the estimate: 10%; at least 1.6-fold (0.22 log units) between middle value and limit.
By their numbers in this assay, from the lowest: compound 2; then compounds 3 and 1 (each within the scatter of the next). At a limit, above all of these: compound 4.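

In this assay compound 4 gives > 100000 nM, which is a limit of the assay and not a number. Putting naphthalen-1-yl in place of 4-(trifluoromethyl)phenyl on a carbonyl carbon, with the count of heavy atoms unchanged, gives an at least 1.2-fold higher number from compound 3 to compound 4 (0.11 log units; that floor lies within the scatter); the true size of this step cannot be read, and its floor alone does not separate the two compounds. The result adds a change of the whole ring on the carbonyl carbon, and it gives no sign of the lower number seen with the addition of a single fluorine, a 3.1-fold lower number from compound 1 to compound 2 (0.50 log units; beyond the scatter).

The two measured steps sit on different backgrounds, one with thiophene and one with furan, and the compounds shown leave open whether the fluorine step would hold with furan, or the naphthalen-1-yl step with thiophene. Also open, going by these compounds, is how the number would respond to a ring on the carbonyl carbon that carries an amine or a carboxylic acid, and whether any such ring would give a number clearly lower than that of compound 2.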